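This account rests on a few compounds, and the source may have more. Where it says the series, first, only, none or still open, it means among the compounds named here.

Compound 1 `C1=C(c2cncc(OCc3ccccc3)c2)CC2CNCC1C2`: 0.7 nM
Compound 2 `C1=C(c2cncc(Oc3ccccc3)c2)CC2CNCC1C2`: 0.7 nM

For the measured compounds named here, in an in vitro assay on SH-EP1 cells for displacement of a labelled ligand from Neuronal acetylcholine receptor; alpha4/beta2 (Homo sapiens) (on this read-out lower numbers stand for stronger inhibition and higher numbers for weaker inhibition), compound 2 gives 0.7 nM, level with compound 1, the only other measured compound, within the scatter of this assay. Going by the values given here, the single measured step, no change at the digits printed from compound 1 to compound 2 (within the scatter), swaps phenyl for benzyl on the oxygen and leaves the read-out at the same digits, so the part of the molecule attached to that oxygen appears to tolerate at least this kind of alteration.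

Compound 3 `Clc1ccccc1Oc1cncc(C2=CC3CNCC(C2)C3)c1` differs from compound 2 by chloro in place of hydrogen on an aromatic carbon, in other words chloro in place of hydrogen on an aromatic carbon. Among the compounds with values here, no measured step touches a substituent on that phenyl ring, so the step from compound 1 to compound 2 bears on it only by showing tolerance in that region. The expectation is therefore a step of a 1.1-fold higher number from compound 2 to compound 3 (0.06 log units; within the scatter) that stays within the scatter. Compound 3 is estimated at 0.8 nM, with a range from 0.3 nM to 2.5 nM.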

Compound 3, inhibition constant: 0.9 nM
Compound 3: the middle estimate sits 1.1-fold (0.05 log units) below what was measured; the range from low to high includes it.
By their numbers in this assay, from the lowest: compounds 1, 2 and 3 (each within the scatter of the next).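

The earlier pair only showed that the group on the oxygen could go from benzyl to phenyl; this result tests a substituent on the phenyl ring itself. In this assay, chloro on an aromatic carbon, ortho to a large group, gives a 1.3-fold higher number from compound 2 to compound 3 (0.11 log units; within the scatter) and so leaves the read-out within the usual spread, while 2-chlorophenyl in place of benzyl on the oxygen gives a 1.3-fold higher number from compound 1 to compound 3 (0.11 log units; within the scatter) and likewise stays within it. Nothing available here explains why the read-out holds across these changes.

On these data alone, it remains open whether a group other than chloro on that ring, such as methoxy, an amine or a carboxylic acid, would be accepted as well. The compounds shown also leave open what chloro would do on other carbons of the ring.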